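The source may hold more compounds than are shown below. What is called first, only, known or untested is meant among the compounds shown, and "the series" means these compounds.

Compound 1 `Nc1scc(CN2CCN(c3ccc(Cl)cc3Cl)CC2)c1C(=O)c1ccc(Cl)cc1` is the starting point in an assay on CHO cells for displacement of a labelled ligand from adenosine receptor A1 (Homo sapiens), read by scintillation counting, with a stated time of 120 min, tested at 10 uM (on this read-out lower numbers stand for less inhibition and higher numbers for more inhibition at the one concentration tested (going by the name of the read-out)), where compound 1 gives 0%, level with compound 2 `COc1ccc(N2CCN(Cc3csc(N)c3C(=O)c3ccc(Cl)cc3)CC2)cc1`, which gives 0%, and close to compound 3 `Nc1scc(CN2CCN(c3ccncc3)CC2)c1C(=O)c1ccc(Cl)cc1`, which gives 1%; the three numbers lie within the scatter of one another. For the measured compounds named here, two steps bear on the change at hand: no change at the digits printed from compound 1 to compound 2 (within the scatter) and a number 1 percentage points higher from compound 1 to compound 3 (within the scatter), each an exchange of the group on the amine nitrogen in the ring. Compound 4 `Nc1scc(CN2CCN(c3ccc(F)c(F)c3)CC2)c1C(=O)c1ccc(Cl)cc1` makes the same kind of exchange: 3,4-difluorophenyl in place of 2,4-dichlorophenyl on an amine nitrogen in a ring. No movement beyond the scatter is expected in this assay because no change at the digits printed from compound 1 to compound 2 (within the scatter) and a number 1 percentage points higher from compound 1 to compound 3 (within the scatter) both stayed flat, so the estimated step is no change at the digits printed from compound 1 to compound 4 (within the scatter). Compound 4 is expected to give 0%, in a range from 0% to 10%.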

Compound 4, a percentage reported as inhibition, at one concentration (the size of the read-out at that concentration, not a potency): 0%
Compound 4: middle estimate and measured number agree at the digits printed, within the range that was stated.
By their numbers in this assay, from the lowest: compounds 1, 2, 4 and 3 (each within the scatter of the next).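

In this assay, the 3,4-difluorophenyl group on the amine nitrogen in the ring fits the flat picture: no change at the digits printed from compound 1 to compound 4 (within the scatter), no change at the digits printed from compound 2 to compound 4 (within the scatter) and a number 1 percentage points lower from compound 3 to compound 4 (within the scatter). Fluorine on the aryl ring therefore separates compound 4 from none of the other three compounds at this position. Nothing given here accounts for this result. On these data alone, all four compounds keep an aromatic ring on that nitrogen, so it remains open whether a benzyl group, an acetyl group or a simple ethyl group there would give a different number.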